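Swapping the pyridinyloxy group for methylamino

A few compounds are considered here, and "the series" means these few. Any claim that something is new, unique, unknown or untested is made for them only; others in the source may bear on it.

Of the compounds shown here, three that share one core have been tested in a functional assay on CHO cells for positive allosteric modulation of metabotropic glutamate receptor 2 (Homo sapiens), read by scintillation counting and GTPgammaS binding, with a stated time of 30 min; on this read-out higher numbers stand for larger maximal responses and lower numbers for smaller maximal responses. Compound 1 `CC(C)CCn1ccc(-c2ccccc2)c(C#N)c1=O` carries only hydrogen on the outer ring and gives 117% in this assay. Compound 2 `CC(C)CCn1ccc(-c2ccc(OCC3CC3)cc2)c(C#N)c1=O` gives 192%, and compound 3 `CC(C)CCn1ccc(-c2ccc(Oc3ccccn3)cc2)c(C#N)c1=O` gives 249%. Compound 3 therefore stands highest of the three: its nearest neighbour is compound 2, and compound 1 lies furthest away. The two steps that build it up are a number 75 percentage points higher from compound 1 to compound 2 (beyond the scatter) and a number 132 percentage points higher from compound 1 to compound 3 (beyond the scatter), and the step between the two substituted compounds is a number 57 percentage points higher from compound 2 to compound 3 (beyond the scatter).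

Compound 4 `CNc1ccc(-c2ccn(CCC(C)C)c(=O)c2C#N)cc1` differs from compound 3 in one place: methylamino in place of (pyridin-2-yl)oxy on an aromatic carbon. The step from compound 1 to compound 3 shows how much the group that now leaves was worth, and the step from compound 1 to compound 2 shows that a smaller group on the same aromatic carbon also lifts the response, though less. A small group entering in place of a larger one is therefore expected to pull the maximal response down in this assay, well beyond the scatter, but not all the way back to compound 1. Compound 4 is expected to give 150%, within 100% to 210%, which means an estimated step of a number 99 percentage points lower from compound 3 to compound 4 (beyond the scatter).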

Compound 4, largest response reached (Emax), in percent of the reference or control that the assay uses: 186%
The estimate for compound 4 lay 36 percentage points below the measured number, within the range that was stated.
By their numbers in this assay, from the lowest: compound 1; then compounds 4 and 2 (each within the scatter of the next); then compound 3.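

In this assay, a group of only two heavy atoms on this aromatic carbon, para to a large group, still gives a clear lift, with a number 69 percentage points higher from compound 1 to compound 4 (beyond the scatter) for the change from hydrogen to methylamino. Nor does the atom that links the group to the ring appear to decide the outcome: a nitrogen-linked group with a hydrogen-bond donor and an oxygen-linked group without one cannot be told apart, with a number 6 percentage points lower from compound 2 to compound 4 (within the scatter) when methylamino replaces cyclopropylmethoxy. Of the three substituents now tested, only (pyridin-2-yl)oxy stands apart from the other two, with a number 63 percentage points lower from compound 3 to compound 4 (beyond the scatter) when methylamino takes its place, so the highest response here belongs to that group rather than to substitution at this carbon in general.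

On these data alone, it remains open whether a dimethylamino group, which has no hydrogen on its nitrogen, would match compound 4, and whether a phenoxy group, which has no ring nitrogen, would match compound 3. The data shown offer no measurement that explains why these groups rank as they do.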